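Chloro in Place of Methyl on the Aryl Ring

This account rests on a few compounds, and the source may have more. Where it says the series, first, only, none or still open, it means among the compounds named here.

Compound 2 `C#CCNC1CCc2c(SCCc3ccc(C)cc3)cccc21` gives 25800 nM in an assay on isolated protein for inhibition of Amine oxidase [flavin-containing] B (Homo sapiens) (on this read-out higher numbers stand for weaker inhibition and lower numbers for stronger inhibition), the lowest of the two numbers measured; compound 1 `C#CCNC1CCc2c(SCCc3ccc(Br)cc3)cccc21` gives 85300 nM. Compound 3 `C#CCNC1CCc2c(SCCc3ccc(Cl)cc3)cccc21` differs from compound 2 by chloro in place of methyl on an aromatic carbon. Among the compounds with values here, the one step bearing on this position is a 3.3-fold lower number from compound 1 to compound 2 (0.52 log units; beyond the scatter), a modest change. Chloro is neither methyl nor bromo, and no measured step compares it with either, so compound 3 is expected to give a number somewhat higher than compound 2, around 42000 nM, with a range of 15000 nM to 110000 nM, a step of a 1.6-fold higher number from compound 2 to compound 3 (0.21 log units; within the scatter).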

Compound 3, half-maximal inhibitory concentration: 10800 nM
Compound 3: middle estimate off by 3.9-fold (0.59 log units), on the high side, outside the stated range (below it).
By their numbers in this assay, from the lowest: compound 3; then compound 2; then compound 1.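

Chloro gives the lowest number of the three groups at this position in this assay, with a 2.4-fold lower number from compound 2 to compound 3 (0.38 log units; beyond the scatter) and a 7.9-fold lower number from compound 1 to compound 3 (0.90 log units; beyond the scatter), so both steps are beyond the scatter. Chloro and bromo stand at opposite ends of the order, with methyl between them in value, so the two halogens do not group together in these compounds. No measured evidence accounts for this order. The compounds shown leave open how fluoro or methoxy would compare at this position, and whether chloro keeps its lead with a longer chain.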